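The source may hold more compounds than are shown below. What is called first, only, known or untested is meant among the compounds shown, and "the series" means these compounds.

Measured so far:
compound 1 `CCSc1ccc([C@H](c2cc3cc(Br)ccc3nc2OC)[C@@](O)(CCN(C)C)c2cccc(F)c2)cn1` — 1.07 h
compound 2 `COc1nc2ccc(Br)cc2cc1[C@@H](c1ccnc(OC)c1OC)[C@@](O)(CCN(C)C)c1cccc(C#N)c1` — 0.617 h

In an ADME assay on microsomes from liver (Homo sapiens) for metabolic stability (on this read-out higher numbers stand for a longer-lived compound and lower numbers for a shorter-lived compound), compound 1 gives 1.07 h, the larger of the two numbers on paper. Compound 2 gives 0.617 h in this assay, and the gap between them lies within the usual scatter of repeated measurements, so no real ranking of the two is claimed.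

Compound 3 `COc1nc2ccc(Br)cc2cc1[C@@H](c1cc(C)c(C)s1)[C@@](O)(CCN(C)C)c1cccc(F)c1` has not yet been run in this assay. Relative to compound 1 it carries the change (4,5-dimethylthiophen-2-yl in place of 6-(ethylsulfanyl)pyridin-3-yl on a saturated chain carbon bound to an aromatic carbon and a saturated chain carbon). Going by the values given here, no pair of measured compounds differing in one place is available, so there is no measured anchor for a change of this kind; the two numbers known are near each other and say little about how far a substituent change can move this read-out.

The expected step from compound 1 to compound 3 in this assay is a 1.2-fold lower number from compound 1 to compound 3 (0.08 log units; within the scatter), small and most likely within the scatter, with no direction asserted. Compound 3 is estimated at 0.9 h in this assay, with a range from 0.4 h to 2 h.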

Compound 3, half-life: 1 h
Estimate against measurement, compound 3: 1.1-fold (0.05 log units) below, within the range that was stated.
By their numbers in this assay, from the lowest: compounds 2, 3 and 1 (each within the scatter of the next).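

At the place on a saturated chain carbon bound to an aromatic carbon and a saturated chain carbon, the only single-place step shown for this assay puts 4,5-dimethylthiophen-2-yl in place of 6-(ethylsulfanyl)pyridin-3-yl and gives a 1.1-fold lower number from compound 1 to compound 3 (0.03 log units; within the scatter). This place therefore accepts a five-membered aromatic ring with 1 hetero atom instead of a six-membered one, with fewer heavy atoms and one hydrogen-bond acceptor fewer, while the two numbers stay within the scatter of each other. Nothing measured bears on why the two groups read alike.

Going by these compounds, whether a thiophene carrying an amine, a carboxylic acid or a longer alkyl chain would also stay within the scatter remains open. One step also cannot show whether this exchange reads the same when other parts of the molecule differ.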